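Bromo for chloro at the assay limit

The source may hold more compounds than are shown below. What is called first, only, known or untested is meant among the compounds shown, and "the series" means these compounds.

Of the compounds shown here, two have been tested so far in a functional assay on PC-3 cells (Homo sapiens) for cytotoxicity, read by MTT assay, with a stated time of 72 h; a higher number here means a weaker inhibitor, a lower number a stronger inhibitor. Compound 1 `CSc1nc(Br)c(C(=O)c2ccccc2)s1` reads > 100000 nM in this test, which is a limit of the assay and not a number. Compound 2 `O=C(c1ccccc1)c1sc(N2CCCC2)nc1Cl` reads > 100000 nM in the same test, and this too is only a limit. Compound 2 therefore offers no exact potency as a starting point, and the overall picture is the limit of > 100000 nM in this assay, at which 2 of the 2 values shown sit, for now.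

Compound 3 `O=C(c1ccccc1)c1sc(N2CCCC2)nc1Br` differs from compound 2 in one place, with bromo in place of chloro on an aromatic carbon. Among the measured compounds shown here, no measured pair yet shows what such a swap does in this assay, so the expectation rests on the starting point alone. No step beyond the usual scatter is expected in either direction, and the assay may well report only a limit again. The expected size of the change is small, with the estimate an at least 1.1-fold lower number from compound 2 to compound 3 (0.04 log units; that floor lies within the scatter) as the working figure. For compound 3 the estimated value is 90000 nM (expected range 30000 nM to 100000 nM).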

Compound 3, half-maximal inhibitory concentration: > 100000 nM
Compound 3: only a limit was reported; the forecaster's own chance of this, stated with the estimate: 70%; middle value at least 1.1-fold (0.04 log units) away from the limit.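

No step from compound 1 or compound 2 to compound 3 can be read, because each of these compounds reports only a limit of the assay and not a number: the limit of > 100000 nM in this assay, at which 3 of the 3 values shown sit.

The compounds shown leave open whether bromo in place of chloro, or pyrrolidin-1-yl in place of methylsulfanyl, changes potency at all, and what exact potency any of the three has.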